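The source may hold more compounds than are shown below. What is called first, only, known or untested is meant among the compounds shown, and "the series" means these compounds.

Three compounds built on one shared core were examined in an assay on HEK293 cells for displacement of a labelled ligand from metabotropic glutamate receptor 5 (Rattus norvegicus); on this read-out lower numbers stand for stronger inhibition and higher numbers for weaker inhibition. Compound 1 `O=C(Nc1cc(-c2ccccc2)nn1-c1ccccc1)c1ccccc1` gives 4180 nM. Compound 2 `O=C(Nc1cc(-c2ccccc2)nn1-c1ccccc1)c1cccc(C(F)(F)F)c1`, with a trifluoromethyl in place of hydrogen on an aromatic carbon, gives 1650 nM, a change described by a 2.5-fold lower number from compound 1 to compound 2 (0.40 log units; beyond the scatter). Compound 3 `NC(=O)c1ccc(C(=O)Nc2cc(-c3ccccc3)nn2-c2ccccc2)cc1` reaches only the limit of this assay, > 10000 nM. On the numbers shown, compound 3 stands at the weak end, as recorded by the limit of > 10000 nM in this assay, at which 1 of the 3 values shown sits; the step of an at least 2.3-fold higher number from compound 1 to compound 3 (0.37 log units; beyond the scatter) and the step of an at least 6.0-fold higher number from compound 2 to compound 3 (0.78 log units; beyond the scatter) both run toward weaker binding.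

Compound 4 `Cc1ccc(C(=O)Nc2cc(-c3ccccc3)nn2-c2ccccc2)cc1C` has not yet been measured. It differs from compound 3 by 3,4-dimethylphenyl in place of 4-carbamoylphenyl on a carbonyl carbon. The measured steps that bear on this change are those leading into compound 3: an at least 2.3-fold higher number from compound 1 to compound 3 (0.37 log units; beyond the scatter), where carbamoyl entered for hydrogen, and an at least 6.0-fold higher number from compound 2 to compound 3 (0.78 log units; beyond the scatter), where the entire aryl group on the carbonyl carbon was exchanged. Removing the carbamoyl is expected to move the number back down. Compound 1, with an unsubstituted phenyl, gave 4180 nM, and compound 2 gave 1650 nM, so a ring carrying two methyls is expected to land in the same region. The expected step is an at least 5.0-fold lower number from compound 3 to compound 4 (0.69 log units; beyond the scatter). Compound 4 is therefore estimated at 2000 nM, within 600 nM to 7000 nM.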

Compound 4, inhibition constant: 430 nM
For compound 4 the middle estimate is 4.7-fold (0.67 log units) above the measured one, outside the stated range (below it).
By their numbers in this assay, from the lowest: compound 4; then compound 2; then compound 1. At a limit, above all of these: compound 3.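

At this position, on a carbonyl carbon whose other neighbour is an amide-type nitrogen, 3,4-dimethylphenyl outperforms both earlier aryl groups without a carbamoyl: a 9.7-fold lower number from compound 1 to compound 4 (0.99 log units; beyond the scatter) against phenyl, and a 3.8-fold lower number from compound 2 to compound 4 (0.58 log units; beyond the scatter) against 3-(trifluoromethyl)phenyl. The earlier compounds had shown only a modest gain from adding trifluoromethyl to this ring, whereas the large step of an at least 23-fold lower number from compound 3 to compound 4 (1.36 log units; beyond the scatter) shows how widely binding can vary with this one group, and compound 3 stands as the case against any idea that substitution on this ring helps in general. The full width of that span stays unknown, for the value of compound 3 is a limit and not a number: the limit of > 10000 nM in this assay, at which 1 of the 4 values shown sits.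

The compounds shown leave open whether both methyls are needed, as a phenyl with a single methyl would show, and how a chloro, a methoxy or an amine on this ring would compare. They also leave open whether groups on the two other phenyl rings of the shared core would change the number by as much as this exchange did.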